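Compound 3 to compound 4: working notes

The source may hold more compounds than are shown below. What is called first, only, known or untested is meant among the compounds shown, and "the series" means these compounds.

Compound 1 `COc1ccccc1N1C(=O)CSC1C(=O)NCCCCc1ccccc1`: > 1000 nM, a limit
Compound 2 `O=C(NCCCCc1ccccc1)c1cc(F)cc(C2SCC(=O)N2c2ccccn2)c1`: 14.2 nM
Compound 3 `O=C(NCCCCn1cccn1)c1cccc(C2SCC(=O)N2c2cccnc2)c1`: > 1000 nM, a limit

All values come from a functional assay on HOS-TE85 cells (Homo sapiens) for inhibition, read by CCK-8 assay, with a stated time of 72 h; on this read-out lower numbers stand for stronger inhibition and higher numbers for weaker inhibition. For the measured compounds named here, compound 2 is the only compound with a number. Compound 3 has no number and stands at the limit of > 1000 nM in this assay, at which 2 of the 3 values shown sit.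

Compound 4 `CCOC(=O)c1sc(N2C(=O)CSC2c2cccc(C(=O)NCCCCn3cccn3)c2)nc1C` differs from compound 3 by 5-(ethoxycarbonyl)-4-methyl-1,3-thiazol-2-yl in place of pyridin-3-yl on an amide-type nitrogen in a ring. Going by the values given here, no measured step covers this change. In this assay no step beyond the scatter is expected, since compound 3 gives only the limit > 1000 nM. The estimated step is a step that the limit leaves unreadable from compound 3 to compound 4. Compound 4 is expected at 1500 nM, with an estimated range of 300 nM to 5000 nM.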

Compound 4, half-maximal inhibitory concentration: 430 nM
Estimate against measurement, compound 4: 3.5-fold (0.54 log units) above; low and high end bracket the measured number.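

In this assay, 5-(ethoxycarbonyl)-4-methyl-1,3-thiazol-2-yl in place of pyridin-3-yl on the amide-type nitrogen gives an at least 2.3-fold lower number from compound 3 to compound 4 (0.36 log units; beyond the scatter). This shows that the group on this nitrogen can move the read-out while the pyrazole-bearing side chain stays the same, and that a larger five-membered aromatic ring is tolerated there. Compound 3 gives only a limit, so the true size of the step stays unknown: the limit of > 1000 nM in this assay, at which 2 of the 4 values shown sit.

Open, from the compounds shown here alone, is whether the thiazole ring or its ethoxycarbonyl group carries the step. A carboxylic acid or a primary amide in place of the ethoxycarbonyl group would separate the two.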